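Furan to Thiophene Swap in a Cytotoxicity Series

The source may hold more compounds than are shown below. What is called first, only, known or untested is meant among the compounds shown, and "the series" means these compounds.

Measured so far in a functional assay on HCT-15 cells (Homo sapiens) for cytotoxicity, read by CCK-8 assay and cell counting, with a stated time of 2 days; a lower number here means a stronger inhibitor, a higher number a weaker inhibitor:
compound 1 `Oc1cccc(-c2cc(-c3ccc(Cl)cc3)nc(-c3cccs3)c2)c1` gives 9280 nM;
compound 2 `Oc1cccc(-c2cc(-c3ccc(Cl)cc3)nc(-c3ccco3)c2)c1` gives 10200 nM;
compound 3 `Oc1cccc(-c2cc(-c3ccco3)nc(-c3ccccc3Cl)c2)c1` gives 2230 nM.

Compound 3 has the lowest number of the three in this assay: compound 1 and compound 2 both sit at higher numbers, and both gaps lie beyond the scatter. For the measured compounds named here, the move from compound 2 to compound 3 a 4.6-fold lower number from compound 2 to compound 3 (0.66 log units; beyond the scatter) is the one step of modest size here.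

Compound 4 `Oc1cccc(-c2cc(-c3ccsc3)nc(-c3ccccc3Cl)c2)c1` differs from compound 3 in one place: thiophen-3-yl in place of furan-2-yl on an aromatic carbon.

Going by the values given here, the step that bears on this change is the one from compound 1 to compound 2 a 1.1-fold higher number from compound 1 to compound 2 (0.04 log units; within the scatter), where a thiophene ring was exchanged for a furan ring at the same kind of position and the number stayed within the scatter. Compound 4 is therefore expected to land close to compound 3, with a step of a 1.0-fold higher number from compound 3 to compound 4 (0.01 log units; within the scatter), not beyond the scatter in either direction. The estimate for compound 4 in this assay is 2300 nM, with a likely range from 1000 nM to 5500 nM.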

Compound 4, half-maximal inhibitory concentration: 2500 nM
For compound 4 the middle estimate is 1.1-fold (0.04 log units) below the measured one; the measured number falls inside the stated range.
By their numbers in this assay, from the lowest: compounds 3 and 4 (each within the scatter of the next); then compounds 1 and 2 (each within the scatter of the next).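

With a 2-chlorophenyl group on the shared core, replacing furan-2-yl with thiophen-3-yl on the aromatic carbon next to the ring nitrogen gives a 1.1-fold higher number from compound 3 to compound 4 (0.05 log units; within the scatter) in this assay. The earlier exchange kept the point of attachment on the five-membered ring and carried a 4-chlorophenyl group, whereas this one swaps oxygen for sulfur and also moves the point of attachment, so a within-scatter result now holds for two such pairs, compounds 1 and 2 and compounds 3 and 4. No measurement shown here explains why this exchange leaves the number within the scatter.

Both groups are five-membered aromatic rings with one hetero atom, so these compounds cannot show whether this carbon would accept something quite different. An amine, a carboxylic acid or a longer alkyl chain in that place remains an open question.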